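The source may hold more compounds than are shown below. What is called first, only, known or untested is meant among the compounds shown, and "the series" means these compounds.

Compound 1 `COc1ccc(/C=C/C(=O)c2ccccc2-c2ccc(F)cc2)cc1OC` is the anchor of this small set. In a functional assay on MCF7 cells (Homo sapiens) for antiproliferative activity, read by sulforhodamine B assay, with a stated time of 48 h (on this read-out lower numbers stand for stronger inhibition and higher numbers for weaker inhibition), compound 1 gives 240 nM. Compound 2 `COc1ccc(/C=C/C(=O)c2ccccc2-c2ccc(F)nc2)cc1OC` carries 6-fluoropyridin-3-yl in place of 4-fluorophenyl on an aromatic carbon, and in this assay compound 2 gives 2800 nM, so that this change made a 12-fold higher number from compound 1 to compound 2 (1.07 log units; beyond the scatter).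

Compound 3 `COc1ccc(C(=O)/C=C/c2ccccc2-c2ccc(F)cc2)cc1` has a different core; how it differs from compound 1 is not broken down here. In this assay compound 3 gives 8800 nM, the highest of the three numbers, above compound 2 and well above compound 1.

Compound 4 `COc1ccc(C(=O)/C=C/c2ccccc2-c2ccc(F)nc2)cc1` stands to compound 3 as compound 2 stands to compound 1: it carries 6-fluoropyridin-3-yl in place of 4-fluorophenyl on an aromatic carbon, the same change at the same place. Compound 4 has not been measured in this assay. Among the compounds with values here, because the one earlier instance of this change made a 12-fold higher number from compound 1 to compound 2 (1.07 log units; beyond the scatter), a step in the same direction is expected from compound 3, though it is estimated to be smaller, a 4.5-fold higher number from compound 3 to compound 4 (0.66 log units; beyond the scatter), since compound 3 already gives a high number at 8800 nM. Compound 4 is therefore expected to give about 40000 nM in this assay, estimated to lie between 12000 nM and 130000 nM.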

Compound 4, half-maximal inhibitory concentration: 13000 nM
For compound 4 the middle estimate is 3.1-fold (0.49 log units) above the measured one; measured number inside the range.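

In this assay, 6-fluoropyridin-3-yl in place of 4-fluorophenyl made a 1.5-fold higher number from compound 3 to compound 4 (0.17 log units; within the scatter), so the large step seen on the core of compound 1 did not carry over in size to the core of compound 3. The size of this step therefore depends on the core, as the two instances show: the same change on two cores in this assay, a 12-fold higher number (1.07 log units; beyond the scatter) from compound 1 to compound 2 and a 1.5-fold higher number (0.17 log units; within the scatter) from compound 3 to compound 4, 7.9-fold (0.90 log units) apart, beyond the scatter of two such steps. This does not show which feature of the cores sets the size of the step, since they are not broken down here, and two instances cannot say what the change would do on any further core.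

On these data alone, it remains open whether an unsubstituted phenyl or pyridin-3-yl ring would show the same dependence on the core as the two fluorinated groups. As far as these compounds go, it is also open how a group of a different kind in place of the 4-fluorophenyl, such as an amine or a carboxylic acid, would fare on either core.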